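The compounds below may be only part of what the source reports. "The series", "measured", "known", "first", "only" and "open" are said of these compounds alone.

Of the compounds shown here, two have been tested so far in a functional assay on A549 cells (Homo sapiens) for antiproliferative activity, read by MTT assay, with a stated time of 48 h; a lower number here means a stronger inhibitor, a higher number a weaker inhibitor. Compound 1 (`O=[N+]([O-])c1cc(C(F)(F)F)cc([N+](=O)[O-])c1Oc1ccc(Cl)cc1/C=N\OCc1ccccc1F`) gives 2570 nM, and compound 2 (`O=[N+]([O-])c1cc(C(F)(F)F)cc([N+](=O)[O-])c1Oc1c(Cl)cc(Cl)cc1/C=N\OCc1ccccc1`) gives 1450 nM. These two values lie within the usual scatter of each other, so compound 2 cannot be ranked apart from compound 1 on these numbers.

Compound 3 (`O=[N+]([O-])c1cc(C(F)(F)F)cc([N+](=O)[O-])c1Oc1c(Cl)cc(Cl)cc1/C=N\OCc1ccccc1F`) is compound 2 with a single change: fluoro in place of hydrogen on an aromatic carbon. This places fluoro in place of hydrogen on an aromatic carbon, ortho to a large group, so that benzyl becomes 2-fluorobenzyl. For the measured compounds named here, no pair of measured compounds differs in one place only, so the size of this step has not been observed directly. Compound 1 already carries the 2-fluorobenzyl group, and its value of 2570 nM stays within the scatter of the value for compound 2. On that basis, no step beyond the scatter is expected in this assay, in either direction. The expected change is small, with an estimated step of a 1.1-fold higher number from compound 2 to compound 3 (0.04 log units; within the scatter). For compound 3 the estimated value is 1600 nM, with an expected range from 750 nM to 3200 nM.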

Compound 3, half-maximal inhibitory concentration: 1230 nM
Compound 3: the middle estimate sits 1.3-fold (0.11 log units) above what was measured; low and high end bracket the measured number.
By their numbers in this assay, from the lowest: compounds 3, 2 and 1 (each within the scatter of the next, the first and the last beyond it).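

In this assay, for the compounds shown here, the change from benzyl to 2-fluorobenzyl gives a 1.2-fold lower number from compound 2 to compound 3 (0.07 log units; within the scatter), the first direct reading of fluoro in place of hydrogen at this place, ortho to a large group, and it shows that this change leaves the number indistinguishable from that of the parent. With the 2-fluorobenzyl group held constant, one added chloro group gives a 2.1-fold lower number from compound 1 to compound 3 (0.32 log units; beyond the scatter), a modest step and the only one of the two that lies beyond the scatter, so among these three compounds a measurable difference appears with the chloro change and not with the fluoro change. No measurement available here bears on why either step has the size it has.

The compounds shown leave open whether a larger or different group at the same place, such as chloro, methoxy or nitrile, would also stay within the scatter of compound 2. They also leave open how the number would respond if the benzyl group gave way to a longer alkyl chain or to a chain ending in an amine.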